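The compounds below may be only part of what the source reports. "The series", "measured", "known", "first", "only" and "open" are said of these compounds alone.

Within the data shown here, in a functional assay on PC-3 cells (Homo sapiens) for cytotoxicity (on this read-out higher numbers stand for an effect only at larger amounts of compound and lower numbers for an effect already at smaller amounts), compound 1 `COC1=C(C)C(=O)/C(=C(O)/C=C/c2ccc(Br)cc2)C(=O)C1(C)C` gives 17.7 ug/mL, which places it at the upper end of the three numbers measured so far. Compound 2 `COC1=C(C)C(=O)/C(=C(O)/C=C/c2cccc(OC)c2)C(=O)C1(C)C` gives 14.3 ug/mL, and 3-methoxyphenyl in place of 4-bromophenyl amounts to a 1.2-fold lower number from compound 1 to compound 2 (0.09 log units; within the scatter). Compound 3 `COC1=C(C)C(=O)/C(=C(O)/C=C/c2ccc(F)cc2)C(=O)C1(C)C` gives 7.2 ug/mL, and fluoro in place of bromo amounts to a 2.5-fold lower number from compound 1 to compound 3 (0.39 log units; beyond the scatter). Compound 4 `CCc1ccc(/C=C/C(O)=C2/C(=O)C(C)=C(OC)C(C)(C)C2=O)cc1` has not yet been measured. It differs from the starting point by ethyl in place of bromo on an aromatic carbon, para to a large group, so that 4-bromophenyl becomes 4-ethylphenyl. Among the measured compounds shown here, the closest precedent is the fluoro swap at that same aromatic carbon, a modest step, while the change of aryl group in compound 2 stayed within the scatter. For the measured compounds named here, no measured compound carries an ethyl group, so these steps offer only loose guidance, and a small move towards a lower number seems the most that can be expected. The expected change is a 1.4-fold lower number from compound 1 to compound 4 (0.13 log units; within the scatter), which would not be a clear shift. Compound 4 is estimated at 13 ug/mL, within an expected range of 6.5 ug/mL to 26 ug/mL.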

Compound 4, concentration for half-maximal effect: 15.1 ug/mL
Compound 4: the middle estimate sits 1.2-fold (0.07 log units) below what was measured; measured number inside the range.
By their numbers in this assay, from the lowest: compounds 3, 2, 4 and 1 (each within the scatter of the next, the first and the last beyond it).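

At the aromatic carbon para to a large group, ethyl in place of bromo produces no shift that stands out from the scatter in this assay (a 1.2-fold lower number from compound 1 to compound 4 (0.07 log units; within the scatter)), even though ethyl brings two heavy atoms where bromo has one. Ethyl in place of fluoro at that same carbon does give a modest step (a 2.1-fold higher number from compound 3 to compound 4 (0.32 log units; beyond the scatter)), so fluoro now stands apart from both bromo and ethyl, while 4-ethylphenyl and 3-methoxyphenyl cannot be told apart (a 1.1-fold higher number from compound 2 to compound 4 (0.02 log units; within the scatter)). Nothing available explains these differences.

From the compounds shown here alone, it remains open whether a longer chain such as butyl, or an amine or a carboxylic acid, at this carbon would read like ethyl and bromo or like fluoro. Chloro, which would test how far the fluoro result extends among halogens, is also absent from the compounds shown.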